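The compounds below may be only part of what the source reports. "The series", "measured", "known", "first", "only" and "open" are said of these compounds alone.

Compound 1, with the structure `Cc1cc(Nc2cc(-c3ccccc3)[nH]n2)n2nc(SCc3ccc(F)cc3)nc2n1`, was tested in an ADME assay on GES1 cells (Homo sapiens) for inhibition, read by MTT assay, with a stated time of 72 h (on this read-out lower numbers stand for stronger inhibition and higher numbers for weaker inhibition), where compound 1 gives 35500 nM. Two related compounds were measured in the same way. Compound 2, `Cc1cc(Nc2cc(-c3ccc(F)cc3)[nH]n2)n2nc(SCc3ccc(Br)cc3)nc2n1`, gives 34200 nM in this assay, and compound 3, `Cc1cc(Nc2ccn(Cc3ccc(C(F)(F)F)cc3)n2)n2nc(SCc3ccc(Br)cc3)nc2n1`, gives 30200 nM in this assay. Among the compounds with values here, of these three numbers, the one for compound 1 is the largest as written, but its distances to compound 2 and to compound 3 both fall within the usual scatter of repeated measurements, so the three compounds cannot be separated on these data; all of them are weak inhibitors in this assay.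

Compound 4, `C=CCSc1nc2nc(C)cc(Nc3cc(-c4ccccc4)[nH]n3)n2n1`, has not yet been measured. It differs from compound 1 in one place: vinyl in place of 4-fluorophenyl on a saturated chain carbon bound to a sulfur. Within the data shown here, no pair of measured compounds shows the effect of such a change, so the expectation rests only on how close the three measured numbers lie to one another. The step from compound 1 to compound 4 is expected to be small, if anything toward a higher number, and likely to remain within the scatter, as expressed by a 1.1-fold higher number from compound 1 to compound 4 (0.05 log units; within the scatter). For compound 4 in this assay the estimate is 40000 nM, expected to lie between 20000 nM and 90000 nM.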

Compound 4, half-maximal inhibitory concentration: > 50000 nM
Compound 4 ended at the assay's limit; the forecaster's own chance of this, stated with the estimate: 25%; middle value at least 1.2-fold (0.09 log units) away from the limit.
By their numbers in this assay, from the lowest: compounds 3, 2 and 1 (each within the scatter of the next). At a limit, above all of these: compound 4.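

In this assay, compound 4 gives > 50000 nM, which is a limit of the assay and not a number. Within the data shown here, this is the first view of a change at this position, on a saturated chain carbon bound to a sulfur, with the rest of the molecule held the same: vinyl in place of 4-fluorophenyl, which removes the aromatic ring from that side chain, gives an at least 1.4-fold higher number from compound 1 to compound 4 (0.14 log units; that floor lies within the scatter). That floor lies within the scatter, so the step may be small or much larger, and all that can be said is that the smaller allyl group did not bring the number down, with the reading resting on a single capped value: the limit of > 50000 nM in this assay, at which 1 of the 4 values shown sits.

As far as these compounds go, how far compound 4 really lies past the limit stays unknown, so the size of the loss, if there is one, cannot be stated. Also open, from the compounds shown here alone, is whether another group in this place, such as an amine, a carboxylic acid or a longer chain, would move the number in either direction.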